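This account rests on a few compounds, and the source may have more. Where it says the series, first, only, none or still open, it means among the compounds named here.

Measured in a functional assay on BaF3 cells (Mus musculus) for inhibition, read by CCK-8 assay, with a stated time of 72 h; a lower number here means a stronger inhibitor of growth, a higher number a weaker inhibitor of growth:
Compound 1 `CNc1cc(Oc2ccc(NC(=O)Nc3ccc(C)c(C(F)(F)F)c3)cc2)ncn1`: > 10000 nM
Compound 2 `Cc1ccc(NC(=O)Nc2ccc(Oc3cc(NCCN)ncn3)cc2)cc1C(F)(F)F`: > 10000 nM

Neither entry is a number. Compound 2 gives > 10000 nM, which is a limit of the assay. Compound 1 gives > 10000 nM, which is also a limit. Compound 2 therefore stands at the limit of > 10000 nM in this assay, at which 2 of the 2 values shown sit, and the data give no position for it beyond that limit.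

The next compound, compound 3 `Cc1ccc(NC(=O)Nc2ccc(Oc3cc(NCCO)ncn3)cc2)cc1C(F)(F)F`, keeps the shared core and changes one group: hydroxy in place of amino on a saturated chain carbon, two bonds along the chain from a nitrogen on an aromatic ring. This places hydroxy in place of amino on a saturated chain carbon, two bonds along the chain from a nitrogen on an aromatic ring.

Going by the values given here, only one measured step bears on this change, and it is a step that the two limits leave unreadable from compound 1 to compound 2. That step introduced the aminomethyl group, but it gives no size to carry forward. Among the compounds with values here, nothing measured so far points to a gain in growth inhibition, so no step beyond the scatter is expected in this assay, and a further limit is the likeliest result.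

The expected step is a number no higher from compound 2 to compound 3 (the limit leaves the size open). For compound 3 the estimated value is 10000 nM. The estimated range for compound 3 runs from 4000 nM to 25000 nM.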

Compound 3, concentration for 50% growth inhibition: > 10000 nM
Compound 3: a limit, no number; the forecaster's own chance of this, stated with the estimate: 85%; the middle value lies on the limit itself.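

In this assay compound 3 gives > 10000 nM, which is a limit of the assay and not a number. No step among compound 1, compound 2 and compound 3 can therefore be read, and all of them stand at the same place: the limit of > 10000 nM in this assay, at which 3 of the 3 values shown sit.

The compounds shown leave open how strongly each inhibits growth, and whether hydroxy in place of amino changes that at all.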